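A Dichlorophenyl Swap on Compound 3

This account rests on a few compounds, and the source may have more. Where it says the series, first, only, none or still open, it means among the compounds named here.

Values in an ADME assay on Vero cells (Chlorocebus sabaeus) for cytotoxicity, read by luminescence, with a stated time of 2 days; on this read-out higher numbers stand for lower toxicity in this test and lower numbers for higher toxicity in this test:
Compound 1 `CCc1nc2ccccc2n1CCCOc1ccccc1`: > 50 uM, a limit of the assay
Compound 2 `Cc1nc2ccccc2n1CCCCOc1ccccc1`: > 50 uM, a limit of the assay
Compound 3 `CCc1nc2ccccc2n1CCCCOc1ccc(C)cc1`: 14 uM

Only one of these three results is an actual number. Compound 3 gives 14 uM. The other two compounds stand at the limit of > 50 uM in this assay, at which 2 of the 3 values shown sit, so compound 3 is the only one whose result falls short of that limit. No two of the measured compounds differ in one place only, so the data do not tie that gap to any single structural feature.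

The next compound to be tested is compound 4 `CCc1nc2ccccc2n1CCCCOc1c(Cl)cccc1Cl`. It differs from compound 3 by having 2,6-dichlorophenyl in place of 4-methylphenyl on an oxygen on a saturated carbon. Among the measured compounds shown here, no measured step shows what such a change does in this assay, so no shift beyond the usual scatter is expected, in either direction. For the measured compounds named here, the expectation is anchored on compound 3 at 14 uM, the one measured neighbour that has a number. The expected change is a 1.1-fold higher number from compound 3 to compound 4 (0.03 log units; within the scatter). Compound 4 is estimated at 15 uM, with an expected range of 6 uM to 45 uM.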

Compound 4, half-maximal toxic concentration: 13 uM
Estimate against measurement, compound 4: 1.2-fold (0.06 log units) above, within the range that was stated.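

In this assay, putting 2,6-dichlorophenyl in place of 4-methylphenyl on an oxygen on a saturated carbon gives a 1.1-fold lower number from compound 3 to compound 4 (0.03 log units; within the scatter). Among the compounds shown here, this is the first step between two measured compounds that differ in one place, and it shows that these two groups cannot be told apart in this read-out, even though one carries two chlorine atoms and the other a methyl group on the six-membered aromatic ring. Compound 1 and compound 2 stay at a limit of the assay, not at a number: the limit of > 50 uM in this assay, at which 2 of the 4 values shown sit.

For the compounds shown here, the step therefore shows only that this one exchange leaves the result within the scatter, and it does not say whether the aromatic ring at this place matters for the read-out at all, nor what separates compound 3 and compound 4 from the two compounds at the limit. An amine or a carboxylic acid on the ring at this place, or a longer chain between the oxygen and the shared core, could each test whether the result at this place can move beyond the scatter in this assay.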